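The source may report more compounds than this note shows. Statements on the series, on what has been measured and on what is new or still open speak of the compounds shown alone.

Working notes on the series in an ADME assay on HepG2 cells (Homo sapiens) for cytotoxicity, read by CellTiter-Glo and ATP content, with a stated time of 72 h; a lower number here means that less compound is needed, a higher number that more compound is needed for the effect. Compound 3 `CN(CC(=O)N1CCN(c2ccc(F)cc2)CC1)C(=O)c1ccc(S(C)(=O)=O)c([N+](=O)[O-])c1` gives 17200 nM, and of the two numbers available it sits alongside compound 2 `CN(Cc1ccccc1F)C(=O)CNC(=O)c1ccc(S(C)(=O)=O)c([N+](=O)[O-])c1`, which gives 11400 nM, the two within the scatter of each other. Compound 1 `CN(Cc1ccccc1F)C(=O)C1CCN(C(=O)c2ccc(S(C)(=O)=O)c([N+](=O)[O-])c2)CC1` reports only a limit in this assay, > 27000 nM; this is the limit of > 27000 nM in this assay, at which 1 of the 3 values shown sits. Among the compounds with values here, no step between measured compounds differing in one place is available, so no measured step size can be quoted.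

Compound 4 `CN(CC(=O)N1CCN(c2ccc(C(F)(F)F)cc2)CC1)C(=O)c1ccc(S(C)(=O)=O)c([N+](=O)[O-])c1` differs from compound 3 by trifluoromethyl in place of fluoro on an aromatic carbon. The pair compound 2 and compound 3, which share the substituted core but differ in more than one place, shows nothing beyond the scatter, and nothing in the series speaks to the size of this particular change. The step of a 1.0-fold higher number from compound 3 to compound 4 (0.02 log units; within the scatter) is therefore expected to stay within the scatter, in no fixed direction. Compound 4 is expected to give 18000 nM, with a range from 8000 nM to 40000 nM, and a fair chance that this assay reports only a limit.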

Compound 4, half-maximal effective concentration: 11900 nM
The estimate for compound 4 lay 1.5-fold (0.18 log units) above the measured number, within the range that was stated.
By their numbers in this assay, from the lowest: compounds 2, 4 and 3 (each within the scatter of the next). At a limit, above all of these: compound 1.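

In this assay, the series now has its first step between compounds that differ in one place, a 1.4-fold lower number from compound 3 to compound 4 (0.16 log units; within the scatter). Within the data shown here, at this position, on an aromatic carbon para to a large group, going from 4-fluorophenyl to 4-(trifluoromethyl)phenyl is therefore a change the assay does not separate from the scatter, which the earlier compounds could not show. Nothing measured here gives a cause for this step.

As far as these compounds go, whether the position stays as insensitive with other groups, such as an amine, a carboxylic acid or a nitrile, remains open, since one change at one position is all that can be read. Compound 1 stands only as a limit, > 27000 nM, and no compound shown differs from it in one place.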